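The source may report more compounds than this note shows. Statements on the series, on what has been measured and on what is new or still open speak of the compounds shown alone.

Working notes on the benzamide series with the shared core of compound 2 `Nc1ccccc1NC(=O)c1ccc(CSc2cccc(F)c2)cc1`.

In a functional assay on SMMC-7721 cells (Homo sapiens) for inhibition, read by CCK-8 assay, with a stated time of 72 h, tested at 2 uM (a lower number here means less inhibition of growth, a higher number more inhibition of growth at the concentration tested), compound 2 gives 18.6%. Compound 3 `CC(C)(C)c1ccc(SCc2ccc(C(=O)Nc3ccccc3N)cc2)cc1` gives 23.6% in this assay, a number within the scatter of compound 2, so the two cannot be ordered. Compound 1 `Nc1ccccc1NC(=O)c1ccc(CSc2nccc(C(F)(F)F)n2)cc1` gives 66.1% in this assay, a number beyond the scatter above both compound 2 and compound 3. Compound 2 thus sits at the low end of the three numbers shown, alongside compound 3.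

Compound 4 `Nc1ccccc1NC(=O)c1ccc(CSCCc2ccccc2)cc1` has not been measured in this assay. It differs from compound 2 in one place: phenethyl in place of 3-fluorophenyl on a sulfur. For the measured compounds named here, no measured pair shows this change, so the expected size of the step is uncertain. Both groups that have been tried on the sulfur with a carbon-only ring, in compound 2 with 18.6% and in compound 3 with 23.6%, gave low numbers, and nothing here points to compound 4 reaching the level of compound 1. The step from compound 2 to compound 4 is expected to be small, a number 6.4 percentage points higher from compound 2 to compound 4 (within the scatter), and not clearly beyond the scatter in either direction. Compound 4 is estimated at 25%, with a range from 8% to 45%.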

Compound 4, percent growth inhibition at one concentration: 28.1%
The estimate for compound 4 lay 3.1 percentage points below the measured number; measured number inside the range.
By their numbers in this assay, from the lowest: compounds 2, 3 and 4 (each within the scatter of the next); then compound 1.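

For the compounds shown here, this is the first pair that differs in one place: in this assay, phenethyl in place of 3-fluorophenyl on a sulfur gives a number 9.5 percentage points higher from compound 2 to compound 4 (within the scatter) and so does not separate the two compounds. A saturated chain carrying the six-membered aromatic ring of carbon only, and the loss of the fluorine, therefore make no readable difference at this position at the tested concentration. No measurement available here explains this result.

Still open, going by these compounds, is whether benzyl, a longer chain such as phenylpropyl, or a group carrying an amine or a carboxylic acid on the sulfur would read differently from compound 4. Also open, on these data alone, is whether trifluoromethyl on a carbon-only ring would approach compound 1 at 66.1% in this assay.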